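A few compounds are considered here, and "the series" means these few. Any claim that something is new, unique, unknown or untested is made for them only; others in the source may bear on it.

Measured compounds:
Compound 1 `C=CCc1ccc(O)c(-c2ccc(OCc3ccccc3)c(CC=C)c2)c1`: 23200 nM
Compound 2 `C=CCc1ccc(OCc2ccc(Cl)c(Cl)c2)c(-c2ccc(OCc3ccc(Cl)c(Cl)c3)c(CC=C)c2)c1`: > 50000 nM, a limit of the assay
Compound 3 `C=CCc1ccc(OCc2ccc(Cl)c(Cl)c2)c(-c2ccc(O)c(CC=C)c2)c1`: 17500 nM

In a functional assay on MCF7 cells (Homo sapiens) for inhibition, read by MTT assay, with a stated time of 72 h (on this read-out higher numbers stand for weaker inhibition and lower numbers for stronger inhibition), compound 3 gives 17500 nM, within the scatter of compound 1 at 23200 nM. Compound 4 `C=CCc1ccc(OCc2ccccc2)c(-c2ccc(O)c(CC=C)c2)c1` has not yet been measured. It differs from compound 3 by phenyl in place of 3,4-dichlorophenyl on a saturated chain carbon bound to an oxygen on an aromatic ring, with phenyl in place of 3,4-dichlorophenyl on a saturated chain carbon bound to an oxygen on an aromatic ring. For the measured compounds named here, the one measured step, an at least 2.8-fold lower number from compound 2 to compound 3 (0.45 log units; beyond the scatter), removes a whole 3,4-dichlorobenzyl, so it bears only loosely on this change. Compound 1, which carries benzyl, gives 23200 nM, and so no step beyond the scatter is expected in this assay. The expected step is a 1.2-fold higher number from compound 3 to compound 4 (0.08 log units; within the scatter). For compound 4 the estimated value is 21000 nM, with an expected range of 10000 nM to 42000 nM.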

Compound 4, half-maximal inhibitory concentration: 22300 nM
Compound 4: middle estimate off by 1.1-fold (0.03 log units), on the low side; the measured number falls inside the stated range.
By their numbers in this assay, from the lowest: compounds 3, 4 and 1 (each within the scatter of the next). At a limit, above all of these: compound 2.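

In this assay, phenyl in place of 3,4-dichlorophenyl on a saturated chain carbon bound to an oxygen on an aromatic ring gives a 1.3-fold higher number from compound 3 to compound 4 (0.11 log units; within the scatter), so this read-out does not tell benzyl from 3,4-dichlorobenzyl at this place. The earlier step took off the whole 3,4-dichlorobenzyl, whereas this one isolates its two chlorines. Nothing shown bears on the reason for this result. From the compounds shown here alone, it remains open whether an amine, a carboxylic acid or a longer chain at this place would give a step beyond the scatter.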